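The source may hold more compounds than are shown below. What is called first, only, known or untested is meant among the compounds shown, and "the series" means these compounds.

Values so far in a functional assay on a cell-free system (plasma, Homo sapiens), with a stated time of 3 min; a lower number here means a stronger inhibitor, a higher number a weaker inhibitor
- compound 1 `O=C(NCc1cc(Cl)ccc1-n1cnnn1)[C@@H]1[C@H]2C[C@H]2CN1C(=O)[C@H](O)c1ccccc1` gives 960 nM
- compound 2 `O=C(NCc1cc(Cl)ccc1-n1cnnn1)[C@@H]1[C@H]2C[C@H]2CN1C(=O)[C@H](O)Cc1ccccc1` gives 1200 nM
- compound 3 `O=C(NCc1cc(Cl)ccc1-n1cnnn1)[C@@H]1[C@@H]2C[C@@H]2CN1C(=O)[C@H](O)Cc1ccccc1` gives 970 nM

Compound 2 lies within the scatter of both compound 1 and compound 3, so these three values cannot be put in order. Compound 4 `CC(C)(C)OC[C@@H](O)C(=O)N1C[C@@H]2C[C@@H]2[C@H]1C(=O)NCc1cc(Cl)ccc1-n1cnnn1` has not yet been measured. It differs from compound 2 (tert-butoxy in place of phenyl on a saturated chain carbon, two bonds along the chain from a carbonyl carbon and an oxygen on a saturated carbon) by having tert-butoxy in place of phenyl on a saturated chain carbon, two bonds along the chain from a carbonyl carbon and an oxygen on a saturated carbon. The nearest measured change lies in the same chain: phenyl gave way to benzyl in the step (a 1.3-fold higher number from compound 1 to compound 2 (0.10 log units; within the scatter)) and that stayed within the scatter. The step (a 1.2-fold lower number from compound 2 to compound 3 (0.09 log units; within the scatter)) comes with the fact that compounds 2 and 3 differ only in the configuration as drawn and was just as small. Neither step replaces an aromatic ring with an open chain, so this evidence is only indirect. With both steps this small, no change beyond the scatter is expected in this assay (a 1.3-fold higher number from compound 2 to compound 4 (0.10 log units; within the scatter)) although the range must stay wide. The estimated value for compound 4 is 1500 nM with 500 nM to 4500 nM as its expected range.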

Compound 4, half-maximal inhibitory concentration: 570 nM
Compound 4: middle estimate off by 2.6-fold (0.42 log units), on the high side; the measured number falls inside the stated range.
By their numbers in this assay, from the lowest: compounds 4, 1, 3 and 2 (each within the scatter of the next, the first and the last beyond it).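

In this assay, for the compounds shown here, the aromatic ring is not needed at this position: replacing phenyl with tert-butoxy, which has no ring, gives a 2.1-fold lower number from compound 2 to compound 4 (0.32 log units; beyond the scatter) and is the first step here to pass the scatter, though only modestly. The earlier compounds had only shown that phenyl and benzyl could not be told apart, so an open group carrying an oxygen is new information about this chain. Measured against the shorter side chain, (tert-butoxy)methyl in place of phenyl gives a 1.7-fold lower number from compound 1 to compound 4 (0.23 log units; within the scatter), so compound 4 and compound 1 cannot be put in order.

Nothing measured here explains why the swap from compound 2 lowers the number. Going by these compounds, whether the ether oxygen or the bulky carbon end matters remains open, and a tert-butyl group, a methoxy group or an amine at this place would help separate the two.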